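A few compounds are considered here, and "the series" means these few. Any claim that something is new, unique, unknown or untested is made for them only; others in the source may bear on it.

Measured in a functional assay on K562 cells (Homo sapiens) for inhibition, read by trypan blue exclusion, with a stated time of 72 h; on this read-out higher numbers stand for weaker inhibition and lower numbers for stronger inhibition:
- compound 1 `Cn1c(=O)c(S(=O)(=O)Cc2ccc(F)cc2F)cc2cnc(Nc3ccc4[nH]ccc4c3)nc21`: 1000 nM
- compound 2 `O=c1c(S(=O)(=O)c2ccc(F)cc2F)cc2cnc(Nc3ccc4[nH]ccc4c3)nc2n1C1CCCC1`: 5000 nM
- compound 3 `Cn1c(=O)c(S(=O)(=O)c2ccccc2)cc2cnc(Nc3ccc4ncccc4c3)nc21`: 100000 nM

Compound 3 has the highest number of the three, which makes it the weakest inhibitor here. Compound 4 `Cn1c(=O)c(S(=O)(=O)c2ccccc2)cc2cnc(Nc3cnc4[nH]ccc4c3)nc21` differs from compound 3 in one group, on a nitrogen on an aromatic ring: a group of 9 heavy atoms (7 carbon, 2 nitrogen; one five-membered aromatic ring with 1 hetero atom, one six-membered aromatic ring with 1 hetero atom) in place of a group of 10 heavy atoms (9 carbon, 1 nitrogen; one six-membered aromatic ring of carbon only, one six-membered aromatic ring with 1 hetero atom), on a nitrogen on an aromatic ring. The quinolin-6-yl leaves, and the group that enters has one five-membered aromatic ring with 1 hetero atom. Compound 1 and compound 2 also carry such a ring in that place, but they differ from compound 3 elsewhere too, so they are only a rough guide. A lower number is therefore expected, moving towards compound 2 at 5000 nM. The expected step is a 17-fold lower number from compound 3 to compound 4 (1.22 log units; beyond the scatter), beyond the scatter. For compound 4 the estimated value is 6000 nM, with an expected range of 1000 nM to 50000 nM.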

Compound 4, half-maximal inhibitory concentration: 5000 nM
Estimate against measurement, compound 4: 1.2-fold (0.08 log units) above; low and high end bracket the measured number.
By their numbers in this assay, from the lowest: compound 1; then compounds 2 and 4 (each within the scatter of the next); then compound 3.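

In this assay, putting the group with a five-membered aromatic ring in place of the quinolin-6-yl, on a nitrogen on an aromatic ring, gives a 20-fold lower number from compound 3 to compound 4 (1.30 log units; beyond the scatter). Among the compounds shown here, this is the first pair differing in one place only, and it shows that the group held there can change the read-out well beyond the scatter. Nothing available explains the change.

The two groups differ in both ring make-up and hydrogen-bond donors, so this pair cannot separate those features. Going by these compounds, how a phenyl ring or a simple amine would behave in that place remains open.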